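The source may report more compounds than this note shows. Statements on the series, on what has been measured and on what is new or still open speak of the compounds shown alone.

Compound 1 `COc1ccc(-c2nc3cc(C(F)(F)F)ccc3[nH]2)c(OC)c1` gives > 100000 nM
Compound 2 `COc1cc(OC)cc(-c2nc3cc(C(F)(F)F)ccc3[nH]2)c1` gives 19000 nM

For the measured compounds named here, in an ADME assay on MT4 cells (Homo sapiens) for cytotoxicity, read by MTT assay, with a stated time of 96 h (a lower number here means that less compound is tolerated, a higher number that more compound is tolerated), compound 2 gives 19000 nM as the only true number so far. For compound 1 the entry > 100000 nM is a limit of the assay and not a number. Compound 2 is therefore the natural starting point for the next compound.

Compound 3 `COc1cc(-c2nc3cc(C(F)(F)F)ccc3[nH]2)cc(OC)c1OC` keeps the core of compound 2 and differs in one place: methoxy in place of hydrogen on an aromatic carbon is a methoxy in place of hydrogen on an aromatic carbon. Going by the values given here, no measured step yet shows what such a change does in this assay and so no clear move in either direction is expected. Among the compounds with values here, the expected step of a 1.3-fold lower number from compound 2 to compound 3 (0.10 log units; within the scatter) stays within the usual scatter, and the estimate is anchored on compound 2 at 19000 nM as its only number. For compound 3 the estimated half-maximal cytotoxic concentration is 15000 nM with an expected range from 4000 nM to 60000 nM in this measurement.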

Compound 3, half-maximal cytotoxic concentration: 4000 nM
Estimate against measurement, compound 3: 3.8-fold (0.57 log units) above; the range from low to high includes it.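

In this assay, putting a methoxy in place of hydrogen on the aromatic carbon that is ortho to two methoxy groups and para to a large group gives a 4.8-fold lower number from compound 2 to compound 3 (0.68 log units; beyond the scatter). For the compounds shown here, this is the first readable step, and it shows that this position is not indifferent to substitution: the cells tolerate less of the compound once the third methoxy is present. Compound 3 has a true number, so the assay's upper limit plays no part in this step: the limit of > 100000 nM in this assay, at which 1 of the 3 values shown sits.

A single step cannot show whether the drop belongs to the methoxy itself or would follow any group placed on this carbon. A hydroxyl, a fluorine or an amine at the same place would help to separate those two readings, and a longer chain such as ethoxy would show whether size matters here.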